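The source may hold more compounds than are shown below. What is called first, only, known or untested is meant among the compounds shown, and "the series" means these compounds.

Working notes on the series. Compound 1 `Cc1ccccc1Nc1nc(Nc2cc(Cl)ccn2)ncc1Cl` in a functional assay on MDA-MB-231 cells (Homo sapiens) for inhibition, read by CCK-8 assay, with a stated time of 48 h (on this read-out higher numbers stand for weaker inhibition of growth and lower numbers for stronger inhibition of growth), gives 52400 nM. Within the data shown here, compound 2 `COc1cccc(CNc2nc(Nc3ccc(N4CCN(C)CC4)cn3)ncc2Cl)c1` in this assay gives 20300 nM, the lower of the two numbers so far, with the gap to compound 1 beyond the usual scatter. Among the measured compounds shown here, no pair of measured compounds differs in one place only, so no single step can be sized from the data. Compound 3 `Cc1cc(C)c(Nc2nc(Nc3ccc(N4CCN(C)CC4)cn3)ncc2Cl)c(C)c1` is not yet measured; it differs from compound 2 by 2,4,6-trimethylphenyl in place of 3-methoxybenzyl on a nitrogen on an aromatic ring. The step from compound 2 to compound 3 is expected to be small, a 1.5-fold higher number from compound 2 to compound 3 (0.17 log units; within the scatter), and not clearly beyond the scatter in either direction. Compound 3 is estimated at 30000 nM in this assay, in the range 8000 nM to 110000 nM.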

Compound 3, concentration for 50% growth inhibition: 21000 nM
The estimate for compound 3 lay 1.4-fold (0.15 log units) above the measured number; measured number inside the range.
By their numbers in this assay, from the lowest: compounds 2 and 3 (each within the scatter of the next); then compound 1.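

With a 1.0-fold higher number from compound 2 to compound 3 (0.01 log units; within the scatter) in this assay for this change, the number at this position, on a nitrogen on an aromatic ring, does not separate 3-methoxybenzyl from 2,4,6-trimethylphenyl. This holds even though the hydrogen-bond acceptor of 3-methoxybenzyl leaves and the aromatic ring of carbon only stays. No measurement at hand offers an explanation for this result. Still open, from the compounds shown here alone, is whether a group of another kind at this nitrogen, such as a simple alkyl chain, a primary amine or a carboxylic acid, would give a step beyond the scatter.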